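The source may hold more compounds than are shown below. What is called first, only, known or untested is meant among the compounds shown, and "the series" means these compounds.

Compound 3 `CC(=O)OC[C@H]1O[C@@H](CC(=O)/C=C/c2ccc(NC(=S)Nc3ccccc3)cc2)[C@H](OC(C)=O)[C@@H](OC(C)=O)[C@@H]1OC(C)=O` and compound 1 `CC(=O)OC[C@H]1O[C@@H](CC(=O)/C=C/c2ccc(NC(=O)Nc3ccccc3)cc2)[C@H](OC(C)=O)[C@@H](OC(C)=O)[C@@H]1OC(C)=O` share one core and differ in a single place, the change (a group of 9 heavy atoms (7 carbon, 1 nitrogen, 1 oxygen; one six-membered aromatic ring of carbon only) in place of a group of 9 heavy atoms (7 carbon, 1 nitrogen, 1 sulfur; one six-membered aromatic ring of carbon only), on a nitrogen on an aromatic ring). In an ADME assay on Vero cells (Chlorocebus sabaeus) for cytotoxicity, read by resazurin assay, with a stated time of 2 days (on this read-out lower numbers stand for higher toxicity in this test and higher numbers for lower toxicity in this test), compound 3 gives 663000 nM, and compound 1 gives 820000 nM; the step of a 1.2-fold higher number from compound 3 to compound 1 (0.09 log units; within the scatter) is the only measured record of this change among the compounds considered here.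

Compound 2 `O=C(/C=C/c1ccc(NC(=S)Nc2ccccc2)cc1)C[C@@H]1O[C@H](CO)[C@@H](O)[C@H](O)[C@H]1O` carries a different core, and how that core differs from the core of compound 3 is not broken down here. In this assay compound 2 gives 274000 nM, the lowest of the three numbers, with compound 3 its nearest neighbour and compound 1 the furthest, both of those gaps lying beyond the usual scatter.

Compound 4 `O=C(/C=C/c1ccc(NC(=O)Nc2ccccc2)cc1)C[C@@H]1O[C@H](CO)[C@@H](O)[C@H](O)[C@H]1O` has not been measured. It stands to compound 2 as compound 1 stands to compound 3: the change (a group of 9 heavy atoms (7 carbon, 1 nitrogen, 1 oxygen; one six-membered aromatic ring of carbon only) in place of a group of 9 heavy atoms (7 carbon, 1 nitrogen, 1 sulfur; one six-membered aromatic ring of carbon only), on a nitrogen on an aromatic ring), at a place described in the same words for both pairs, so this is the same change made on the core of compound 2. Going by the values given here, because the first instance of this change moved the number only by a 1.2-fold higher number from compound 3 to compound 1 (0.09 log units; within the scatter), a step of similar size is expected from compound 2 to compound 4, that is a 1.2-fold higher number from compound 2 to compound 4 (0.08 log units; within the scatter). On that basis compound 4 is estimated to give 330000 nM in this assay, with a plausible range from 150000 nM to 700000 nM.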

Compound 4, half-maximal cytotoxic concentration: 1130000 nM
For compound 4 the middle estimate is 3.4-fold (0.53 log units) below the measured one, and the stated range ends below it.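

In this assay, the phenylcarbamoyl group in place of its sulfur-bearing counterpart, on a nitrogen on an aromatic ring, gave a 4.1-fold higher number from compound 2 to compound 4 (0.62 log units; beyond the scatter), and this step did not match the one recorded on the other core: the same change on two cores in this assay, a 1.2-fold higher number (0.09 log units; within the scatter) from compound 3 to compound 1 and a 4.1-fold higher number (0.62 log units; beyond the scatter) from compound 2 to compound 4, 3.3-fold (0.52 log units) apart, beyond the scatter of two such steps

The size of this change therefore did not carry from one core to the other, so a step read on the core of compound 3 proved a poor guide to the same step on the core of compound 2. This does not show which feature of the cores lies behind the gap or how the change would behave on any further core, since the comparison rests on just two pairs of compounds, one with a step within the scatter and one with a step beyond it.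

The compounds shown leave open whether a third core, for instance one with methyl ethers or benzoyl groups on its oxygens, would follow the smaller step, the larger one or neither. They also leave open whether the gap persists when the outer phenyl ring carries an amine or a carboxylic acid.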